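Nitro substitution and solubility across two quinolinone cores

A few compounds are considered here, and "the series" means these few. Any claim that something is new, unique, unknown or untested is made for them only; others in the source may bear on it.

Compound 1 `CCOCCCCc1cc(=O)c2ccccc2[nH]1` and compound 2 `CCOCCCCc1cc(=O)c2cc([N+](=O)[O-])ccc2[nH]1` share one core, while compound 3 `CCCCCCCc1[nH]c2ccccc2c(=O)c1C(=O)OCC` and the as-yet unmeasured compound 4 `CCCCCCCc1[nH]c2ccc([N+](=O)[O-])cc2c(=O)c1C(=O)OCC` share another; the difference between the two cores is not broken down here. In a physicochemical assay for solubility, read by HPLC, at pH 7.4 (on this read-out lower numbers stand for lower solubility and higher numbers for higher solubility), compound 1 sits at the limit of the method, giving > 200000 nM, which is a limit rather than a number. In this assay compound 2 gives 50000 nM. The change between them is nitro in place of hydrogen on an aromatic carbon, and it produced an at least 4.0-fold lower number from compound 1 to compound 2 (0.60 log units; beyond the scatter), a step that can only be given as a lower bound, since compound 1 rests on (the limit of > 200000 nM in this assay, at which 1 of the 3 values shown sits). In this assay compound 3 gives 5000 nM, the lowest of the two numbers recorded. Compound 4 carries the same change, (nitro in place of hydrogen on an aromatic carbon), made on the other core. He expects the step from compound 3 to compound 4 to resemble the earlier one, estimating a 4.2-fold lower number from compound 3 to compound 4 (0.62 log units; beyond the scatter), resting on the drop seen from compound 1 to compound 2. Compound 4 is therefore expected to give about 1200 nM, most plausibly between 300 nM and 5000 nM.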

Compound 4, solubility: 5000 nM
Beside the measured number, compound 4's estimate is 4.2-fold (0.62 log units) below it, within the range that was stated.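

In this assay, nitro in place of hydrogen on an aromatic carbon gives no change at the digits printed from compound 3 to compound 4 (within the scatter), whereas the same change on the other core gave an at least 4.0-fold lower number from compound 1 to compound 2 (0.60 log units; beyond the scatter). Across these two pairs, then, the change did not carry over as a drop of similar size: a step beyond the scatter on one core has no counterpart beyond the scatter on the other. This does not show how the change behaves on any further core or establish why the two pairs part, and the size of the first step remains open, as the value of compound 1 is a limit and not a number: the limit of > 200000 nM in this assay, at which 1 of the 4 values shown sits.

The compounds shown leave open whether an amine or a carboxylic acid, set in place of the nitro, would follow either pair. They also leave open whether the outcome on the core of compound 3 would hold with a longer chain or without the ethyl ester.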